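Methyl replaces (tert-butyl)carbamoyl on a ring amine nitrogen

A few compounds are considered here, and "the series" means these few. Any claim that something is new, unique, unknown or untested is made for them only; others in the source may bear on it.

Going by the values given here, in a physicochemical assay for solubility (a higher number here means a more soluble compound, a lower number a less soluble compound), compound 2 `CC(C)(C)NC(=O)N1CCC[C@H]1C(=O)N1CCC(NS(=O)(=O)c2cc(S(=O)(=O)c3ccccc3)ccc2C(F)(F)F)CC1` gives 50000 nM and has only one measured neighbour. Compound 1 `O=C(CN1CCCC1)N1CCC(NS(=O)(=O)c2cc(S(=O)(=O)c3ccccc3)ccc2C(F)(F)F)CC1` gives 25000 nM and the two lie within the scatter of each other.

Compound 3 `CN1CCC[C@H]1C(=O)N1CCC(NS(=O)(=O)c2cc(S(=O)(=O)c3ccccc3)ccc2C(F)(F)F)CC1` differs from compound 2 in one place, with methyl in place of (tert-butyl)carbamoyl on an amine nitrogen in a ring and the rest of the molecule unchanged.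

Among the compounds with values here, the one measured step that bears on this change is a 2.0-fold higher number from compound 1 to compound 2 (0.30 log units; within the scatter) for 1-((tert-butyl)carbamoyl)pyrrolidin-2-yl in place of (pyrrolidin-1-yl)methyl on a carbonyl carbon, so no change beyond the scatter is expected in this assay here. The estimated size is a 1.4-fold lower number from compound 2 to compound 3 (0.15 log units; within the scatter) for this swap. For compound 3 the expected value is 35000 nM with a range from 15000 nM to 80000 nM around it.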

Compound 3, solubility: 100000 nM
Compound 3: middle estimate off by 2.9-fold (0.46 log units), on the low side; the measured number lies above the stated range.
By their numbers in this assay, from the lowest: compounds 1, 2 and 3 (each within the scatter of the next, the first and the last beyond it).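

In this assay, putting methyl in place of (tert-butyl)carbamoyl on the amine nitrogen in the ring gives a 2.0-fold higher number from compound 2 to compound 3 (0.30 log units; within the scatter), so removing this larger group leaves no change that can be told from the scatter. The comparison with the open-chain side group goes further: 1-methylpyrrolidin-2-yl in place of (pyrrolidin-1-yl)methyl on a carbonyl carbon gives a 4.0-fold higher number from compound 1 to compound 3 (0.60 log units; beyond the scatter), a modest step and the first here to clear the scatter. Nothing measured here accounts for either step.

On this ring nitrogen the compounds shown carry only methyl and (tert-butyl)carbamoyl, so it remains open how a plain hydrogen, an ethyl group or an acetyl group would read. Going by these compounds, it also remains open whether the modest step would hold with a different group on the shared core.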